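Cyclopentyl for Butyl on the Fused Ring Nitrogen

A few compounds are considered here, and "the series" means these few. Any claim that something is new, unique, unknown or untested is made for them only; others in the source may bear on it.

Of the compounds shown here, three built on a shared core have been tested in a functional assay on NCI-H460 cells (Homo sapiens) for antiproliferative activity, read by CCK-8 assay, with a stated time of 72 h, tested at 8 uM; a higher number here means a stronger effect of the compound at the concentration tested, a lower number a weaker effect. Compound 1 `Nc1ccccc1NC(=O)/C=C/c1ccc(COCNc2nc(Nc3cccc(Cl)c3)c3ncn(C4CCCC4)c3n2)cc1` gives 46.1%. Compound 2 `Nc1ccccc1NC(=O)c1ccc(COCNc2nc(Nc3ccccc3)c3ncn(C4CCCC4)c3n2)cc1` gives 56.1%. Compound 3 `CCCCn1cnc2c(Nc3ccccc3)nc(NCOCc3ccc(/C=C/C(=O)Nc4ccccc4N)cc3)nc21` gives 34.2%, the lowest of the three readings: compound 1 sits above it by a gap beyond the scatter, and compound 2 sits further above, also beyond the scatter.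

Compound 4 `Nc1ccccc1NC(=O)/C=C/c1ccc(COCNc2nc(Nc3ccccc3)c3ncn(C4CCCC4)c3n2)cc1` has not yet been measured. It differs from compound 3 in one place: cyclopentyl in place of butyl on an aromatic nitrogen. Among the compounds with values here, no measured pair in this set carries this change alone, so the size of the step cannot be read from a measured comparison. What can be said is that compound 1 and compound 2, which both carry cyclopentyl on that aromatic nitrogen, gave the two higher readings, while compound 3 with butyl gave the lowest. On that basis the step of a number 12.8 percentage points higher from compound 3 to compound 4 (beyond the scatter) is expected to run upward by a moderate amount, plausibly beyond the scatter, though the two cyclopentyl compounds also differ from compound 3 elsewhere. Compound 4 is therefore estimated at 47%, with a range from 33% to 61%.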

Compound 4, a percentage reported as inhibition, at one concentration (the size of the read-out at that concentration, not a potency): 59.7%
Beside the measured number, compound 4's estimate is 12.7 percentage points below it; low and high end bracket the measured number.
By their numbers in this assay, from the lowest: compound 3; then compounds 1, 2 and 4 (each within the scatter of the next, the first and the last beyond it).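

In this assay, within the data shown here, the exchange of butyl for cyclopentyl on an aromatic nitrogen of the five-membered aromatic ring now has a measured size of a number 25.5 percentage points higher from compound 3 to compound 4 (beyond the scatter) with all else held constant, which the earlier compounds, differing in more than one place, could not give. Two further single changes can now be read on the same compound: hydrogen in place of chloro on an aromatic carbon amounts to a number 13.6 percentage points higher from compound 1 to compound 4 (beyond the scatter) and so also counts at this concentration, whereas 2-((2-aminophenyl)carbamoyl)ethenyl in place of (2-aminophenyl)carbamoyl on an aromatic carbon amounts to a number 3.6 percentage points higher from compound 2 to compound 4 (within the scatter) and so separates the two compounds by no more than the usual scatter. Nothing available here accounts for any of these steps.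

With only butyl and cyclopentyl shown on that nitrogen, it remains open how a cyclohexyl ring, an isopropyl group or a longer chain would read there. Fluoro or methoxy on the aromatic carbon that carries chloro in compound 1 is equally open, and each step rests on one read-out at one concentration, which gives no potency.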